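Returning a Chloro to the Carbonyl-Bound Group

This account rests on a few compounds, and the source may have more. Where it says the series, first, only, none or still open, it means among the compounds named here.

Three compounds share one core and differ only in the group on the carbonyl carbon. In a functional assay on PC-3 cells (Homo sapiens) for antiproliferative activity, read by MTT assay, with a stated time of 48 h (on this read-out lower numbers stand for stronger inhibition and higher numbers for weaker inhibition), compound 2 `O=C(/C=C/c1ccc(/C=C/C(=O)c2ccc(Cl)cc2)o1)NO` gives 1350 nM, compound 3 `Cc1ccc(C(=O)/C=C/c2ccc(/C=C/C(=O)NO)o2)cc1` gives 16000 nM, and compound 1 `O=C(/C=C/c1ccc(/C=C/C(=O)c2cc(Cl)ccc2Cl)o1)NO` gives 24700 nM. Compound 3 thus stands second highest of the three numbers, near compound 1 and far from compound 2. Among the compounds with values here, one measured step bears on the present change: a 12-fold higher number from compound 2 to compound 3 (1.07 log units; beyond the scatter). Compound 4 `O=C(/C=C/c1ccc(/C=C/C(=O)c2cccc(Cl)c2)o1)NO` is not yet measured; it carries 3-chlorophenyl in place of 4-methylphenyl on a carbonyl carbon. Because the step of a 12-fold higher number from compound 2 to compound 3 (1.07 log units; beyond the scatter) was large and upward, the return of a chloro in compound 4 is expected to move the number downward, though compound 4 carries 3-chlorophenyl rather than the 4-chlorophenyl of compound 2, so a full reversal is not assumed. Compound 4 is therefore estimated at 4500 nM, with a range from 1200 nM to 17000 nM. This estimate corresponds to an expected step of a 3.6-fold lower number from compound 3 to compound 4 (0.55 log units; beyond the scatter).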

Compound 4, half-maximal inhibitory concentration: 9600 nM
Beside the measured number, compound 4's estimate is 2.1-fold (0.33 log units) below it, within the range that was stated.
By their numbers in this assay, from the lowest: compound 2; then compounds 4, 3 and 1 (each within the scatter of the next, the first and the last beyond it).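

In this assay, 3-chlorophenyl in place of 4-methylphenyl on the carbonyl carbon gives a 1.7-fold lower number from compound 3 to compound 4 (0.22 log units; within the scatter) and so lies within the scatter, which shows that a chloro on this group does not by itself bring the number back to that of compound 2. Within the data shown here, the placement of the chloro on this group counts, since 3-chlorophenyl in place of 4-chlorophenyl gives a 7.1-fold higher number from compound 2 to compound 4 (0.85 log units; beyond the scatter) and is the first measured comparison of a chloro moved on this group. Hydrogen in place of chloro gives a 2.6-fold lower number from compound 1 to compound 4 (0.41 log units; beyond the scatter) and so shows that the extra chloro of compound 1 does not help in this set.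

No measurement at hand explains these differences. A 3-methylphenyl or 3-methoxyphenyl group on the carbonyl carbon would show whether the 3-chlorophenyl result is specific to chloro.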